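Compound 3: A Sulfur-Linked Ring at the Assay Limit

The source may hold more compounds than are shown below. What is called first, only, known or untested is meant among the compounds shown, and "the series" means these compounds.

In an ADME assay on MDCK cells (Canis lupus familiaris) for cytotoxicity, read by MTT assay, with a stated time of 48 h (a lower number here means that less compound is tolerated, a higher number that more compound is tolerated), compound 1 (`CCC(CC)O[C@@H]1C=C(C(=O)O)C[C@H](NCc2ccc(OC)cc2)[C@H]1NC(C)=O`) gives > 250000 nM, which is a limit of the assay. Compound 2 (`CCC(CC)Oc1ccc(CN[C@H]2CC(C(=O)O)=C[C@@H](OC(CC)CC)[C@@H]2NC(C)=O)cc1`) gives > 250000 nM, also a limit and not a number. Compound 3 (`CCC(CC)O[C@@H]1C=C(C(=O)O)C[C@H](NCc2ccc(SC3CCCCC3)cc2)[C@H]1NC(C)=O`) carries cyclohexylsulfanyl in place of (pentan-3-yl)oxy on an aromatic carbon. Among the measured compounds shown here, the only measured step that bears on this change is a step that the two limits leave unreadable from compound 1 to compound 2, and it has no readable size. What stands on record is the limit of > 250000 nM in this assay, at which 2 of the 2 values shown sit. No step beyond the scatter is therefore expected, and the estimate is a number no higher from compound 2 to compound 3 (the limit leaves the size open). Compound 3 is expected at 250000 nM, within an estimated range of 100000 nM to 500000 nM.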

Compound 3, half-maximal cytotoxic concentration: > 250000 nM
Compound 3: a limit, no number (the forecaster's own chance of this, stated with the estimate: 75%); the middle value lies on the limit itself.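

Compound 1, compound 2 and compound 3 all end at a limit of the assay and not at a number, so no step among them can be read: the limit of > 250000 nM in this assay, at which 3 of the 3 values shown sit.

In this assay, from the compounds shown here alone, the concentration at which any of the three stops being tolerated stays open, as does whether the group on the aromatic carbon affects it.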